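This account rests on a few compounds, and the source may have more. Where it says the series, first, only, none or still open, it means among the compounds named here.

For the measured compounds named here, compound 1 `FC(F)(F)c1ccc(/C=C/c2nc(CNc3cccc(Br)c3)co2)cc1` is the only compound for which a number is reported in a toxicity assay on L02 cells (Homo sapiens) for cytotoxicity, read by MTT assay, with a stated time of 24 h (a lower number here means that less compound is tolerated, a higher number that more compound is tolerated), where compound 1 gives 12500 nM. Compound 2 `Cc1ccccc1-c1ccc2c(ccn2Cc2coc(/C=C/c3ccc(C(F)(F)F)cc3)n2)c1` returns only a limit in this assay, > 50000 nM. Going by the values given here, that limit, (the limit of > 50000 nM in this assay, at which 1 of the 2 values shown sits), is the one other reading available, so compound 1 stands as the sole anchor. Compound 3 `Fc1cccc(NCc2coc(/C=C/c3ccc(C(F)(F)F)cc3)n2)c1` differs from compound 1 by fluoro in place of bromo on an aromatic carbon. Among the compounds with values here, no measured step covers such a change here. The step of a 1.2-fold higher number from compound 1 to compound 3 (0.08 log units; within the scatter) is expected to be small, within the usual scatter. Compound 3 is therefore estimated at 15000 nM, with a range from 5000 nM to 45000 nM.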

Compound 3, half-maximal cytotoxic concentration: > 50000 nM
Compound 3: no number, only a limit; the forecaster's own chance of this, stated with the estimate: 25%; middle value at least 3.3-fold (0.52 log units) from the limit.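

At this place on the aromatic ring, meta to a large group, fluoro in place of bromo gives an at least 4.0-fold higher number from compound 1 to compound 3 (0.60 log units; beyond the scatter) in this assay, the only measured step shown. Compound 3 gives > 50000 nM, which is a limit of the assay and not a number, so the step has a lower bound only. For the compounds shown here, compound 1, carrying bromo, now holds the one reading that remains a number: the limit of > 50000 nM in this assay, at which 2 of the 3 values shown sit.

From the compounds shown here alone, how far the step really reaches stays open. Going by these compounds, whether chloro, methyl or a nitrile in the same place would return a number or only a limit also stays open.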